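The source may report more compounds than this note shows. Statements on the series, on what has been measured and on what is new or still open speak of the compounds shown alone.

In a functional assay on MCF7 cells (Homo sapiens) for antiproliferative activity, read by MTT assay, with a stated time of 72 h; a higher number here means a weaker inhibitor, a lower number a stronger inhibitor:
compound 1 `COc1ccc(/C=C2\S/C(=N\c3ccc(Cl)cc3)N(C)C2=O)cc1`: 39300 nM
compound 2 `FC(F)(F)c1cc(/N=C2/NC/C(=C/c3ccccc3)S2)cc(C(F)(F)F)c1`: 13500 nM
compound 3 `COc1ccc(/C=C2\S/C(=N\c3ccc(C(C)(C)C)cc3)N(C)C2=O)cc1`: > 100000 nM, a limit of the assay

Of the two exact numbers, compound 1 holds the higher, at 39300 nM. Compound 4 `COc1ccc(/C=C2\S/C(=N\c3c(C)cccc3C)N(C)C2=O)cc1` has not yet been measured. Its change from compound 1 is 2,6-dimethylphenyl in place of 4-chlorophenyl on a double-bonded nitrogen. For the measured compounds named here, one measured step bears on it, since that change also removes the chloro: tert-butyl in place of chloro gave an at least 2.5-fold higher number from compound 1 to compound 3 (0.40 log units; beyond the scatter). A single step gives only weak guidance, so the change in this assay is expected to be small, leaning towards a higher number. The estimated change is a 1.3-fold higher number from compound 1 to compound 4 (0.10 log units; within the scatter). For compound 4 the estimate is 50000 nM, with an expected range of 20000 nM to 110000 nM.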

Compound 4, half-maximal inhibitory concentration: > 100000 nM
Compound 4: a limit, no number (the forecaster's own chance of this, stated with the estimate: 30%); middle value at least 2.0-fold (0.30 log units) from the limit.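

In this assay, 2,6-dimethylphenyl in place of 4-chlorophenyl gives an at least 2.5-fold higher number from compound 1 to compound 4 (0.40 log units; beyond the scatter), so a second replacement at this position also weakens the compound beyond the scatter. Compound 3 showed this only for tert-butyl in place of chloro, whereas compound 4 extends it to a change that removes the chloro and brings in two methyl groups. Compound 3 and compound 4 cannot be ranked against each other, and the full size of each step stays unread: the limit of > 100000 nM in this assay, at which 2 of the 4 values shown sit.

The compounds shown leave open whether a fluoro, an amine or a carboxylic acid on this phenyl ring would keep or lower the number of compound 1.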